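The source may hold more compounds than are shown below. What is called first, only, known or untested is meant among the compounds shown, and "the series" means these compounds.

In a functional assay on SK-MEL-5 cells (Homo sapiens) for inhibition, read by sulforhodamine B assay, with a stated time of 48 h (on this read-out higher numbers stand for weaker inhibition of growth and lower numbers for stronger inhibition of growth), compound 1 `O=C(Cc1csc2nc(-c3ccc(Br)cc3)cn12)N/N=C/c1ccccc1` gives 5620 nM, compound 2 `O=C(Cc1csc2nc(-c3ccc(Br)cc3)cn12)N/N=C/c1ccccc1O` gives 2950 nM and compound 3 `COc1cccc(OC)c1/C=N/NC(=O)Cc1csc2nc(-c3ccc(Br)cc3)cn12` gives 8910 nM. Within the data shown here, compound 3 stands apart from only one neighbour: a 1.6-fold higher number from compound 1 to compound 3 (0.20 log units; within the scatter) stays within the scatter, while a 3.0-fold higher number from compound 2 to compound 3 (0.48 log units; beyond the scatter) goes beyond it. Compound 4 `O=C(Cc1csc2nc(-c3ccc(Br)cc3)cn12)N/N=C/c1ccc(Cl)cc1Cl` carries 2,4-dichlorophenyl in place of 2,6-dimethoxyphenyl on a carbon with a double bond to nitrogen. The measured changes at this place bear on it, and they are small, with a 1.9-fold lower number from compound 1 to compound 2 (0.28 log units; within the scatter) as the third. Among the measured compounds shown here, no measured compound carries chlorine on that ring, so the direction is weakly founded. The expected result is small and leans to a lower number, a 1.9-fold lower number from compound 3 to compound 4 (0.27 log units; within the scatter). Compound 4 is estimated at 4800 nM, with an expected range of 2000 nM to 11000 nM.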

Compound 4, concentration for 50% growth inhibition: 44700 nM
Compound 4: the middle estimate sits 9.3-fold (0.97 log units) below what was measured; the whole stated range lies below it.
By their numbers in this assay, from the lowest: compounds 2, 1 and 3 (each within the scatter of the next, the first and the last beyond it); then compound 4.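

In this assay, an 8.0-fold higher number from compound 1 to compound 4 (0.90 log units; beyond the scatter) and a 5.0-fold higher number from compound 3 to compound 4 (0.70 log units; beyond the scatter) and also a 15-fold higher number from compound 2 to compound 4 (1.18 log units; beyond the scatter) all follow the entry of 2,4-dichlorophenyl on the carbon with a double bond to nitrogen. This group thus gives the first clear loss against every other ring at this place, and compound 4 is the weakest of the four. Nothing available accounts for this loss. Open, from the compounds shown here alone, is how a ring carrying a single chlorine, a methyl group or an amine would read here. Also open, going by these compounds, is whether a hydroxy group added to the 2,4-dichlorophenyl ring would bring the number down.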